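Adding a third methoxy to the lactam analogue

The source may hold more compounds than are shown below. What is called first, only, known or untested is meant among the compounds shown, and "the series" means these compounds.

Compound 1 `COc1cc(/C=C/C2CC=CC(=O)O2)cc(OC)c1OC` and compound 2 `COc1cc(/C=C/C2CC=CC(=O)N2)cc(OC)c1` were tested in a functional assay on MCF7 cells (Homo sapiens) for inhibition, read by sulforhodamine B assay, with a stated time of 48 h; a lower number here means a stronger inhibitor of growth, a higher number a weaker inhibitor of growth. Compound 1 gives 15.3 uM, while compound 2 gives 146 uM, the highest of the two numbers and well beyond the scatter from compound 1. Compound 3 `COc1cc(/C=C/C2CC=CC(=O)N2)cc(OC)c1OC` has not yet been measured. It differs from compound 2 by one change: methoxy in place of hydrogen on an aromatic carbon. For the measured compounds named here, no single-change step between measured compounds shows the effect of this change, since compound 1 differs from compound 2 in two places. A modest lowering of the number is expected, so the step of a 2.1-fold lower number from compound 2 to compound 3 (0.32 log units; beyond the scatter) is an estimate only. Compound 3 is expected to give 70 uM, within 25 uM to 200 uM.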

Compound 3, concentration for growth inhibition (reported as GI): > 864 uM
Compound 3: a limit, no number (the forecaster's own chance of this, stated with the estimate: 5%); middle value at least 12-fold (1.09 log units) from the limit.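

Compound 3 carries a limit, not a number: the limit of > 864 uM in this assay, at which 1 of the 3 values shown sits.

At the aromatic carbon ortho to two methoxy groups, methoxy in place of hydrogen weakens growth inhibition, with an at least 5.9-fold higher number from compound 2 to compound 3 (0.77 log units; beyond the scatter). With that methoxy present, a single change can now be read in the six-membered non-aromatic ring group, where a nitrogen replaces an oxygen, giving an at least 56-fold higher number from compound 1 to compound 3 (1.75 log units; beyond the scatter).

On these data alone, whether a hydroxyl, a fluorine or an amine at this aromatic carbon would also weaken growth inhibition stays open. So does the effect of a methyl on the ring nitrogen.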